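The source may report more compounds than this note shows. Statements on the series, on what has been measured and on what is new or still open speak of the compounds shown alone.

Measured in a functional assay on HCT-116 cells (Homo sapiens) for antiproliferative activity, read by CCK-8 assay, with a stated time of 72 h, tested at 2 uM; a higher number here means a stronger effect of the compound at the concentration tested, a lower number a weaker effect:
- compound 1 `Nc1ccccc1NC(=O)/C=C/c1ccc(Cn2cnc3c(Nc4cccc(Cl)c4)nc(Cl)nc32)cc1` gives 12.9%
- compound 2 `CCC(C)n1cnc2c(NCc3ccc(C(=O)Nc4ccccc4N)cc3)nc(Cl)nc21` gives 74.6%
- compound 3 `Nc1ccccc1NC(=O)c1ccc(COCNc2nc(Nc3ccccc3)c3ncn(C4CCCC4)c3n2)cc1` gives 75.2%

Compound 2 sits at the upper end of the three numbers in this assay. Its nearest neighbour is compound 3, whose value lies within the scatter of that of compound 2, so the two cannot be ordered. Compound 1 is the furthest away, with a value that falls far below that of compound 2, well beyond the scatter. Among the compounds with values here, no pair among the three differs in one place only, so no single step is available for calibration.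

Compound 4 `CC(C)n1cnc2c(NCc3ccc(C(=O)Nc4ccccc4N)cc3)nc(Cl)nc21` is the next compound, not yet measured in this assay. It differs from compound 2 as follows: hydrogen in place of methyl on a saturated chain carbon, two bonds along the chain from an aromatic nitrogen. Cut one bond further out, the change reads sec-butyl to isopropyl.

The change removes one carbon from the saturated chain and adds nothing else; no donor or acceptor moves. A change of this size on an alkyl chain is expected to give a step of a number 4.6 percentage points lower from compound 2 to compound 4 (within the scatter) that stays within the scatter, with no clear direction. Compound 4 is therefore estimated at 70%, with a range from 50% to 85%, leaning on compound 2 and its value 74.6%.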

Compound 4, a percentage reported as inhibition, at one concentration (the size of the read-out at that concentration, not a potency): 73.2%
Compound 4: the middle estimate sits 3.2 percentage points below what was measured; measured number inside the range.
By their numbers in this assay, from the lowest: compound 1; then compounds 4, 2 and 3 (each within the scatter of the next).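

In this assay, within the data shown here, the first pair that differs in one place reads a number 1.4 percentage points lower from compound 2 to compound 4 (within the scatter), so sec-butyl and isopropyl cannot be told apart on this measure. Among these compounds, this gives the series its first calibration: at the saturated chain carbon two bonds along the chain from an aromatic nitrogen, exchanging methyl for hydrogen removes one carbon, with no hydrogen-bond donor or acceptor entering or leaving, and produces no step that can be resolved from the scatter. No measured information is available that would account for this result.

The compounds shown span only this small change on the alkyl chain, so it remains open whether a longer chain, or an amine or a carboxylic acid carried on the chain, would also leave the read-out within the scatter of compound 2. Going by these compounds, it also remains open whether compound 2 and compound 4 would stay inseparable across a range of concentrations, since a percentage inhibition at a single concentration gives the size of the effect there and not a potency.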